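Thiophenyl replacement at the aryl position of compound 3

The compounds below may be only part of what the source reports. "The series", "measured", "known", "first", "only" and "open" are said of these compounds alone.

Working notes on the series. In a functional assay on HCT-116 cells (Homo sapiens) for inhibition, read by sulforhodamine B assay, with a stated time of 48 h, tested at 10 uM (a higher number here means more inhibition at the concentration tested (going by the name of the read-out), a lower number less inhibition), compound 1 `O=Cc1ccc(-c2cn3ccnc3c(-c3ccc4ncn(C5CCCCC5)c4c3)n2)cc1` gives 92.6%, compound 2 `Fc1ccc(-c2cn3ccnc3c(-c3ccc4ncn(C5CCCCC5)c4c3)n2)cc1` gives 18% and compound 3 `Clc1ccc(-c2cn3ccnc3c(-c3ccc4ncn(C5CCCCC5)c4c3)n2)cc1` gives 7.34%. Compound 3 stands lowest of the three numbers; its nearest neighbour is compound 2, and the gap a number 10.7 percentage points lower from compound 2 to compound 3 (beyond the scatter) is beyond the scatter, while a number 85.3 percentage points lower from compound 1 to compound 3 (beyond the scatter) and a number 74.6 percentage points lower from compound 1 to compound 2 (beyond the scatter) are large. Among the measured compounds shown here, compound 4 `c1csc(-c2cn3ccnc3c(-c3ccc4ncn(C5CCCCC5)c4c3)n2)c1` is unmeasured; the change thiophen-2-yl in place of 4-chlorophenyl on an aromatic carbon swaps the whole aryl group, whereas every measured step only varied the substituent on that phenyl, so no step bears on it directly. In this assay a step of roughly a number 7.7 percentage points higher from compound 3 to compound 4 (within the scatter) is expected, small relative to the scatter. Compound 4 is therefore estimated at 15%, within 0% to 45%.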

Compound 4, a percentage reported as inhibition, at one concentration (the size of the read-out at that concentration, not a potency): 21.1%
Beside the measured number, compound 4's estimate is 6.1 percentage points below it, within the range that was stated.
By their numbers in this assay, from the lowest: compound 3; then compounds 2 and 4 (each within the scatter of the next); then compound 1.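

In this assay the swap of the whole aryl group gives a reading on a five-membered ring at this position: thiophen-2-yl in place of 4-chlorophenyl (a number 13.8 percentage points higher from compound 3 to compound 4 (beyond the scatter)) is a modest step, and thiophen-2-yl in place of 4-fluorophenyl (a number 3.1 percentage points higher from compound 2 to compound 4 (within the scatter)) stays within the scatter. Thiophen-2-yl remains far from 4-formylphenyl (a number 71.5 percentage points lower from compound 1 to compound 4 (beyond the scatter)), so this ring does not recover the reading of compound 1. No measurement available here explains these steps.

Going by these compounds, whether the high reading needs the formyl group itself remains open. An amine or a carboxylic acid on the phenyl, or a formyl group on the thiophene, would bear on that.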